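A few compounds are considered here, and "the series" means these few. Any claim that something is new, unique, unknown or untested is made for them only; others in the source may bear on it.

Working notes on the series. In a functional assay on FaDu cells (Homo sapiens) for cytotoxicity, read by MTT assay, with a stated time of 72 h (on this read-out higher numbers stand for lower toxicity in this test and lower numbers for higher toxicity in this test), compound 1 `COc1ccc(NC(=O)C(=O)c2cn(C(C)C)c3c(Cl)cccc23)cn1` gives 10200 nM. Compound 2 `COc1ccc(NC(=O)C(=O)c2cn(CC(C)(C)OC)c3ccccc23)cn1` is known only as a limit, > 10000 nM, and has no exact number on this read-out. Compound 3 `COc1ccc(NC(=O)C(=O)c2cn(CCOC(C)C)c3ccccc23)cn1` has the same atoms as compound 2, joined differently: isopropoxymethyl in place of 1-methoxy-1-methylethyl on a saturated chain carbon bound to an aromatic nitrogen. The same difference, cut one bond further out, reads 2-methoxy-2-methylpropyl to 2-isopropoxyethyl. Among the compounds with values here, no measured step gives a size for this change. The expected step that the limit leaves unreadable from compound 2 to compound 3 is none beyond the scatter, with no direction favoured in this assay. For compound 3 the estimate is 11000 nM, with an expected range of 5000 nM to 20000 nM.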

Compound 3, concentration lethal to 50% of the cells: 211 nM
Beside the measured number, compound 3's estimate is 52-fold (1.72 log units) above it, and the stated range ends above it.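

On the saturated chain carbon bound to an aromatic nitrogen, the arrangement of the same atoms matters in this assay: isopropoxymethyl in place of 1-methoxy-1-methylethyl gives an at least 47-fold lower number from compound 2 to compound 3 (1.67 log units; beyond the scatter). Compound 2 is known only as a limit, so this step is a bound and not an exact size: the limit of > 10000 nM in this assay, at which 1 of the 3 values shown sits. Within the data shown here, the earlier compounds gave no step at this position, and this pair is the first to show that an isomeric change there can move the number beyond the scatter.

On these data alone, whether a longer chain or an amine at this place keeps the lower number remains open. As far as these compounds go, whether the same change carries over to the core of compound 1 also remains open.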